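The source may hold more compounds than are shown below. What is called first, only, known or untested is meant among the compounds shown, and "the series" means these compounds.

Compound 3 `CCN(CC)CCCn1c(=O)c(=Cc2ccccc2O)s/c1=C1\C(=O)Nc2ccc(C)cc21` is the reference point. In a functional assay on MDA-MB-231 cells (Homo sapiens) for inhibition, read by MTT assay, with a stated time of 72 h (on this read-out higher numbers stand for weaker inhibition and lower numbers for stronger inhibition), compound 3 gives 15900 nM. Compound 2 `CCN(CC)CCCn1c(=O)c(=Cc2ccccc2O)s/c1=C1\C(=O)Nc2ccc(Br)cc21` gives 19900 nM in this assay, and the two numbers sit within the usual scatter of each other. Putting methyl in place of bromo on an aromatic carbon gives a 1.3-fold lower number from compound 2 to compound 3 (0.10 log units; within the scatter). Compound 1 `CCN(CC)CCCn1c(=O)c(=Cc2cc(OC)c(OC)c(OC)c2)s/c1=C1\C(=O)Nc2ccc(C)cc21` reaches only the assay limit, > 200000 nM, in this assay. Swapping that 3,4,5-trimethoxyphenyl for 2-hydroxyphenyl gives an at least 12-fold lower number from compound 1 to compound 3 (1.09 log units; beyond the scatter). Compound 4 `CCN(CC)CCCn1c(=O)c(=Cc2ccccc2O)s/c1=C1\C(=O)Nc2ccccc21` differs from compound 3 by hydrogen in place of methyl on an aromatic carbon. Within the data shown here, the only measured step at this position, the bromo-to-methyl exchange, stayed within the scatter, so no step beyond the scatter is expected here either. Compound 4 is therefore estimated to give 17000 nM, within 8000 nM to 36000 nM. That expected outcome corresponds to a 1.1-fold higher number from compound 3 to compound 4 (0.03 log units; within the scatter).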

Compound 4, half-maximal inhibitory concentration: > 200000 nM
Compound 4: no number, only a limit (the forecaster's own chance of this, stated with the estimate: 5%); middle value at least 11-fold (1.07 log units) from the limit.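

In this assay, this aromatic carbon proves more sensitive than the exchange of bromo for methyl suggested: removing the substituent altogether gives an at least 12-fold higher number from compound 3 to compound 4 (1.09 log units; beyond the scatter) and an at least 10-fold higher number from compound 2 to compound 4 (1.00 log units; beyond the scatter). Methyl and bromo give values within the scatter of each other, so on these compounds either group keeps a measurable number, while hydrogen does not. Compound 4 has only a limit rather than a number: the limit of > 200000 nM in this assay, at which 2 of the 4 values shown sit.

Going by these compounds, how far past that limit compound 4 lies remains unknown. Also open, on these data alone, is whether an amine or a nitrile at this carbon would behave like methyl and bromo or like hydrogen.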